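The source may hold more compounds than are shown below. What is called first, only, known or untested is meant among the compounds shown, and "the series" means these compounds.

In a functional assay on NCI-H322M cells (Homo sapiens) for cytotoxicity, read by sulforhodamine B assay, with a stated time of 48 h, tested at 0.01 uM (on this read-out higher numbers stand for a weaker effect at the one concentration tested and lower numbers for a stronger effect), compound 1 `COc1cc(-c2cc(/C=C/C(=O)c3ccc(N)cc3)[nH]n2)cc(OC)c1OC` gives 95%, the highest of the three numbers shown, though compound 2 `COc1ccc(-c2cc(/C=C/C(=O)c3ccc(OC)c(OC)c3)[nH]n2)cc1` with 94% and compound 3 `COc1cc(-c2cc(/C=C/C(=O)c3ccc(Cl)c(Cl)c3)[nH]n2)cc(OC)c1OC` with 89% both lie within the scatter of it. Going by the values given here, the only single-point step measured here is a number 6 percentage points lower from compound 1 to compound 3 (within the scatter), and it concerns the group on the carbonyl carbon, not the change in question. Compound 4 `COc1ccc(-c2cc(/C=C/C(=O)c3ccc(N)cc3)[nH]n2)cc1OC` differs from compound 1 by hydrogen in place of methoxy on an aromatic carbon. Among the compounds with values here, no measured pair isolates this change; compound 2 carries a different methoxy pattern and a different group on the carbonyl carbon, so it bears only loosely. Within the data shown here, with every value so far near the top of the scale, compound 4 is expected to give 94%, within a range of 85% to 100%, which would mean an expected step of a number 1 percentage points lower from compound 1 to compound 4 (within the scatter).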

Compound 4, a percentage reported as activity, at one concentration (the size of the read-out at that concentration, not a potency): 96%
Estimate against measurement, compound 4: 2 percentage points below; the range from low to high includes it.
By their numbers in this assay, from the lowest: compounds 3, 2, 1 and 4 (each within the scatter of the next).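

In this assay, going by these compounds alone, the change gives a number 1 percentage points higher from compound 1 to compound 4 (within the scatter), the first measured step at this position. At the one concentration tested, the core of compound 1 therefore reads the same with methoxy or hydrogen on this aromatic carbon, and both numbers stay near the top of the scale. Nothing available explains this result. The compounds shown leave open whether an ethoxy group or an amine on this carbon would move the number. They also leave open whether compound 1 and compound 4 would stay together under conditions that give a stronger effect.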